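This account rests on a few compounds, and the source may have more. Where it says the series, first, only, none or still open, it means among the compounds named here.

In a functional assay on U-87MG ATCC cells for inhibition, with U-87 MG (Homo sapiens) as the target, read by MTT assay, with a stated time of 48 h (on this read-out higher numbers stand for weaker inhibition and lower numbers for stronger inhibition), the measured compounds are:

Compound 1 `Cc1ccc(-c2nc3ccccn3c2Sc2ccccc2)cc1`: > 100000 nM, a limit of the assay
Compound 2 `COc1ccc(-c2nc3ccccn3c2Sc2ccccc2)cc1`: > 100000 nM, a limit of the assay

Compound 1 has no number on this read-out, only (the limit of > 100000 nM in this assay, at which 2 of the 2 values shown sit). Compound 3 `Cc1ccc(-c2nc3ccc(C)cn3c2Sc2ccccc2)cc1` keeps the core of compound 1 and carries one change: methyl in place of hydrogen on an aromatic carbon. In words, a methyl takes the place of a hydrogen on an aromatic carbon of the six-membered aromatic ring with 1 nitrogen, which is part of a fused system of two rings.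

Within the data shown here, only one measured step bears on this change, and it bears on it weakly. It is a step that the two limits leave unreadable from compound 1 to compound 2, which swaps methoxy for methyl at a different place, so it offers no size to carry over. Compound 2 is likewise known only as the limit > 100000 nM. With no readable step to go on, no step beyond the usual scatter is expected in this assay, and a further report of the limit is the likeliest outcome. The estimated step is a number no higher from compound 1 to compound 3 (the limit leaves the size open). For compound 3 the expected value is 100000 nM, with an estimated range from 40000 nM to 200000 nM.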

Compound 3, half-maximal inhibitory concentration: 82100 nM
Estimate against measurement, compound 3: 1.2-fold (0.09 log units) above, within the range that was stated.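

In this assay, a methyl on this aromatic carbon of the six-membered aromatic ring with 1 nitrogen, two atoms from the ring nitrogen, gives the first compound shown with a number rather than a limit. The change reads as an at least 1.2-fold lower number from compound 1 to compound 3 (0.08 log units; that floor lies within the scatter), so the measurement fixes only a floor for the step, and that floor does not set compound 3 apart from compound 1 beyond the usual scatter. The true size of the step stays unknown, since compound 1 has only a limit and the read-out offers a number for compound 3 alone: the limit of > 100000 nM in this assay, at which 2 of the 3 values shown sit.

The step from compound 1 to compound 2 cannot be read, so the swap of methoxy for methyl adds nothing on size and gives no second change to set beside this one. As far as these compounds go, whether an amine, a carboxylic acid or a longer chain on this same aromatic carbon would move the number further from the limit, and whether a methyl here would do the same on the methoxy compound, compound 2, remains open.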